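The compounds below may be only part of what the source reports. "The series", "measured", "known", "first", "only" and "open" are said of these compounds alone.

Measured so far in an ADME assay on microsomes from liver (Rattus norvegicus) for metabolic stability, read by LC-MS, using NADPH, with stated times of 10 min and 60 min; a higher number here means that the compound lasts longer, a lower number that the compound disappears faster
compound 1 `CN1CCN(c2cc(CN(C)C3CCCc4cccnc43)nc(C3CC3)n2)CC1` gives 0.017 h
compound 2 `COc1nc(CN(C)C2CCCc3cccnc32)cc(N2CCN(C)CC2)n1` gives 0.0367 h
compound 3 `CCN1CCN(c2cc(CN(C)[C@H]3CCCc4cccnc43)nc(C)n2)CC1` gives 0.019 h

Compound 3 (0.019 h) lies within the scatter of both other values, so it has no clear rank among the three. Going by the values given here, the only measured step, with methoxy in place of cyclopropyl on an aromatic carbon, is a 2.2-fold higher number from compound 1 to compound 2 (0.33 log units; beyond the scatter) and it is modest.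

Compound 4 `Cc1nc(CN(C)[C@H]2CCCc3cccnc32)cc(N2CCN3CCC[C@H]3C2)n1` remains unmeasured. Its change from compound 3 is a group of 9 heavy atoms (7 carbon, 2 nitrogen; one five-membered non-aromatic ring with 1 hetero atom, one six-membered non-aromatic ring with 2 hetero atoms) in place of a group of 8 heavy atoms (6 carbon, 2 nitrogen; one six-membered non-aromatic ring with 2 hetero atoms), on an aromatic carbon on an aromatic carbon, where the 4-ethylpiperazin-1-yl group leaves. Among the compounds with values here, no measured step alters that group, so the single step above bears on this change only indirectly, as a guide to how far one substitution has moved the series.

On that thin evidence, no move beyond the scatter is expected in this assay and the estimated change is a 1.1-fold higher number from compound 3 to compound 4 (0.02 log units; within the scatter) here. For compound 4 the estimated half-life is 0.02 h with an expected range from 0.01 h to 0.045 h in this assay.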

Compound 4, half-life: < 0.0167 h
Compound 4 gave a limit, no number; the forecaster's own chance of this, stated with the estimate: 5%; middle value at least 1.1-fold (0.07 log units) from the limit.
By their numbers in this assay, from the lowest: compounds 1, 3 and 2 (each within the scatter of the next, the first and the last beyond it). At a limit, below all of these: compound 4.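

In this assay compound 4 gives < 0.0167 h, which is a limit of the assay and not a number. Going by these compounds alone, the one earlier step altered a different place, whereas this change acts on the group at the position opposite the ring nitrogen and gives an at least 1.1-fold lower number from compound 3 to compound 4 (0.05 log units; that floor lies within the scatter), so swapping 4-ethylpiperazin-1-yl for the group with the added five-membered ring brings no rise in half-life. Whether the drop goes beyond the scatter stays undecided, because the reading ends at a limit: the limit of < 0.0167 h in this assay, at which 1 of the 4 values shown sits.

Open, from the compounds shown here alone, is how a morpholine or a piperazine carrying a hydroxyethyl chain would behave at this position. Also open, going by these compounds, is whether methoxy in place of the methyl group would raise the half-life of compound 4 as it did with cyclopropyl in a 2.2-fold higher number from compound 1 to compound 2 (0.33 log units; beyond the scatter).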